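Compound 3: swapping chloro for methoxy at the assay limit

This account rests on a few compounds, and the source may have more. Where it says the series, first, only, none or still open, it means among the compounds named here.

- Compound 1 `COc1ccc(-c2nc3cc(C(C)=O)ccc3n2C2CCCCC2)cc1` gives > 100000 nM as a limit
- Compound 2 `C/C(=N\NC(N)=S)c1ccc2c(c1)nc(-c1ccc(Cl)cc1)n2C1CCCCC1` gives > 100000 nM as a limit

Both entries come from an ADME assay on MDBK cells (Bos taurus) for cytotoxicity, read by MTT assay, with a stated time of 96 h (on this read-out higher numbers stand for lower toxicity in this test and lower numbers for higher toxicity in this test), and neither is a number. In this assay compound 2 stands at > 100000 nM as a limit of the assay. Compound 1 offers no firmer point of comparison, so the measured picture amounts to the limit of > 100000 nM in this assay, at which 2 of the 2 values shown sit, and nothing more.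

Compound 3 `COc1ccc(-c2nc3cc(/C(C)=N/NC(N)=S)ccc3n2C2CCCCC2)cc1` differs from compound 2 in one place. It has methoxy in place of chloro on an aromatic carbon, para to a large group, so that 4-chlorophenyl becomes 4-methoxyphenyl methoxy in place of chloro on an aromatic carbon in an otherwise unchanged structure.

Going by the values given here, no measured pair shows what this swap does in this assay. With compound 2 at > 100000 nM as its only anchor, no change beyond the usual scatter is expected, in either direction. The expected a number no higher from compound 2 to compound 3 (the limit leaves the size open) is accordingly small, and a further limit is the likeliest report. For compound 3 the estimate is 100000 nM with an expected range of 40000 nM to 200000 nM in this test.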

Compound 3, half-maximal cytotoxic concentration: 32000 nM
The estimate for compound 3 lay 3.1-fold (0.49 log units) above the measured number, outside the stated range (below it).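

In this assay, 4-methoxyphenyl in place of 4-chlorophenyl gives an at least 3.1-fold lower number from compound 2 to compound 3 (0.49 log units; beyond the scatter), so this place, on an aromatic carbon para to a large group, can move the read-out towards higher toxicity in this test. The other changed site of compound 3 does the same: with 4-methoxyphenyl kept, a group of 7 heavy atoms in place of a group of 3 heavy atoms on an aromatic carbon gives an at least 3.1-fold lower number from compound 1 to compound 3 (0.49 log units; beyond the scatter), so among the compounds shown a number appears only where methoxy and the larger group occur together. Both steps are open-ended in size because their starting compounds give no number: the limit of > 100000 nM in this assay, at which 2 of the 3 values shown sit.

From the compounds shown here alone, what stays open is how large either step really is, and whether the link between the two sites holds beyond these three compounds. Going by these compounds, it is also open whether a hydroxyl, a dimethylamino group or a plain hydrogen at the same place would read like methoxy or like chloro, and whether a smaller ring or a short alkyl chain in place of the cyclohexyl group would shift the value of compound 3.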